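Swapping a Fluoro for a Methoxy on the Benzyl Ring

A few compounds are considered here, and "the series" means these few. Any claim that something is new, unique, unknown or untested is made for them only; others in the source may bear on it.

Measured so far:
- compound 1, `COc1ccc(CNc2nc3cc(N)cc(N)c3nc2-c2ccccc2)cc1OC`: 13500 nM
- compound 2, `Nc1cc(N)c2nc(-c3ccccc3)c(NCc3ccc(F)cc3)nc2c1`: 3800 nM

Both compounds were tested in a functional assay on UO-31 cells (Homo sapiens) for inhibition, read by sulforhodamine B assay, with a stated time of 48 h; a higher number here means a weaker inhibitor of growth, a lower number a stronger inhibitor of growth. Among the measured compounds shown here, compound 2 gives the lowest number of the two; its only neighbour is compound 1, and the step of a 3.6-fold lower number from compound 1 to compound 2 (0.55 log units; beyond the scatter) separates them. That step came from exchanging a 3,4-dimethoxyphenyl for a 4-fluorophenyl on the chain carbon bound to the ring nitrogen.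

Compound 3, `COc1ccc(CNc2nc3cc(N)cc(N)c3nc2-c2ccccc2)cc1`, has not yet been measured. It differs from compound 2 by methoxy in place of fluoro on an aromatic carbon, so it sits between the two measured compounds in structure: one methoxy where compound 1 carries two and compound 2 carries none. For the measured compounds named here, the step from compound 1 to compound 2 is the only guide, and it was modest. Since compound 3 undoes part of that change, the expectation is a modest rise in this assay, by roughly a 1.8-fold higher number from compound 2 to compound 3 (0.27 log units; within the scatter), landing short of compound 1. The estimate for compound 3 is therefore 7000 nM, with a likely range from 3000 nM to 16000 nM.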

Compound 3, concentration for 50% growth inhibition: 11500 nM
The estimate for compound 3 lay 1.6-fold (0.22 log units) below the measured number; the range from low to high includes it.
By their numbers in this assay, from the lowest: compound 2; then compounds 3 and 1 (each within the scatter of the next).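

Exchanging the 4-fluorobenzyl of compound 2 for the 4-methoxybenzyl of compound 3 gives a 3.0-fold higher number from compound 2 to compound 3 (0.48 log units; beyond the scatter) in this assay, so a change of one small group on the benzyl ring, para to a large group, is enough on its own to move the number beyond the scatter. Taking away the second methoxy gives a 1.2-fold lower number from compound 1 to compound 3 (0.07 log units; within the scatter), which means that compound 1 and compound 3 cannot be told apart here, and the gap that first appeared between compound 1 and compound 2 follows the exchange of fluoro for methoxy at this place, not the count of methoxy groups. No measurement shown here explains why the fluoro compound gives the lower number.

As far as these compounds go, with only fluoro and methoxy compared at this place, it remains open whether fluoro itself matters or whether a chloro, a hydroxyl or a plain hydrogen there would give a number as low as that of compound 2. From the compounds shown here alone, it is also open whether this difference between fluoro and methoxy would hold on a different core or in other cell lines, and a single pair of compounds in one assay cannot settle that.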